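Biphenyl for bromophenyl: a step at the benzylic aryl

A few compounds are considered here, and "the series" means these few. Any claim that something is new, unique, unknown or untested is made for them only; others in the source may bear on it.

Measured so far:
compound 1, `CC(C)(C)c1ccc(CNCCCNS(=O)(=O)c2cc(C(F)(F)F)cc(C(F)(F)F)c2)cc1`, 2300 nM
compound 2, `COc1ccc(CNCCCNS(=O)(=O)c2cc(C(F)(F)F)cc(C(F)(F)F)c2)cc1OC`, 3400 nM
compound 3, `O=S(=O)(NCCCNCc1ccc(Br)cc1)c1cc(C(F)(F)F)cc(C(F)(F)F)c1`, 2100 nM

All three were read in a functional assay on U-87MG ATCC cells for inhibition, with U-87 MG (Homo sapiens) as the target, read by MTT assay, with a stated time of 72 h; a higher number here means a weaker inhibitor of growth, a lower number a stronger inhibitor of growth. Compound 3 carries the lowest of the three numbers, yet the gaps are small: a 1.1-fold lower number from compound 1 to compound 3 (0.04 log units; within the scatter) and a 1.6-fold lower number from compound 2 to compound 3 (0.21 log units; within the scatter). Compound 4, `O=S(=O)(NCCCNCc1ccc(-c2ccccc2)cc1)c1cc(C(F)(F)F)cc(C(F)(F)F)c1`, differs from compound 3 by phenyl in place of bromo on an aromatic carbon. Both measured steps that touch this position, from the tert-butyl of compound 1 and from the 3,4-dimethoxyphenyl of compound 2, stayed within the scatter, so no change beyond the scatter is expected here either, in neither direction. Compound 4 is therefore estimated at 2100 nM, within 800 nM to 5500 nM, which means an expected step of no change at the digits printed from compound 3 to compound 4 (within the scatter).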

Compound 4, concentration for 50% growth inhibition: 2200 nM
Beside the measured number, compound 4's estimate is 1.0-fold (0.02 log units) below it; the measured number falls inside the stated range.
By their numbers in this assay, from the lowest: compounds 3, 4, 1 and 2 (each within the scatter of the next).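

In this assay, replacing bromo with phenyl gives a 1.0-fold higher number from compound 3 to compound 4 (0.02 log units; within the scatter) and replacing tert-butyl with phenyl gives a 1.0-fold lower number from compound 1 to compound 4 (0.02 log units; within the scatter) without either step leaving the scatter. Among the compounds shown here, this aromatic carbon, para to a large group, thus carries a whole six-membered aromatic ring of carbon only, six heavy atoms where bromo has one, with no measurable step, which the smaller groups of the earlier compounds could not show. From the compounds shown here alone, whether a carboxylic acid or an amine at this carbon would behave alike remains open. Nothing available explains why these numbers stay so close.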